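The source may report more compounds than this note shows. Statements on the series, on what has been measured and on what is new or still open speak of the compounds shown alone.

Compound 1 `CC(C)(C)Cc1c(-c2ccoc2)sc(N)c1C(=O)c1ccc(Cl)cc1` shows 1% in an assay on CHO cells for displacement of a labelled ligand from adenosine receptor A1 (Homo sapiens), read by scintillation counting, tested at 10 uM; a lower number here means less inhibition, a higher number more inhibition at the concentration tested (going by the name of the read-out). Compound 2 `COc1cccc(-c2sc(N)c(C(=O)c3ccc(Cl)cc3)c2CC(C)(C)C)c1` shows 1% in this assay, and the step of no change at the digits printed from compound 1 to compound 2 (within the scatter) left the read-out where it was. Compound 2 therefore stands level with compound 1, both at the bottom of the scale. Compound 3 `Cc1cccc(-c2sc(N)c(C(=O)c3ccc(Cl)cc3)c2CC(C)(C)C)c1` differs from compound 2 by methyl in place of methoxy on an aromatic carbon. Among the measured compounds shown here, no measured step touches this exact group; the only step available, no change at the digits printed from compound 1 to compound 2 (within the scatter), exchanged a whole ring without moving the number. Compound 3 is thus expected to show a number 2 percentage points higher from compound 2 to compound 3 (within the scatter) in this assay. Compound 3 is estimated at 3%, between 0% and 15%.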

Compound 3, a percentage reported as inhibition, at one concentration (the size of the read-out at that concentration, not a potency): 1%
Compound 3: middle estimate off by 2 percentage points, on the high side; the range from low to high includes it.
By their numbers in this assay, from the lowest: compounds 1, 2 and 3 (each within the scatter of the next).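

Putting 3-methylphenyl in place of 3-methoxyphenyl gives no change at the digits printed from compound 2 to compound 3 (within the scatter) in this assay, so a change to one small group reads the same as the earlier exchange of a whole ring. The ring exchange now has a second example, no change at the digits printed from compound 1 to compound 3 (within the scatter), and all three compounds sit at the bottom of the scale. Nothing available explains why these numbers coincide.

With every value this low, these compounds cannot show whether this position can influence the read-out at all. From the compounds shown here alone, whether an amine or a carboxylic acid on this ring would raise the number remains open.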